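This account rests on a few compounds, and the source may have more. Where it says the series, first, only, none or still open, it means among the compounds named here.

In a functional assay on MCF7 cells (Homo sapiens) for cytotoxicity, read by MTT assay, with a stated time of 48 h (on this read-out lower numbers stand for stronger inhibition and higher numbers for weaker inhibition), three compounds have been measured: compound 1 `O=C1/C(=C\c2ccccc2)S/C(=N/c2ccccc2)N1Cc1ccncc1` gives 26400 nM, compound 2 `O=C1/C(=C\c2ccc(O)c(O)c2)S/C(=N/c2ccccc2)N1Cc1ccncc1` gives 12400 nM, and compound 3 `COc1cc(/C=C2/S/C(=N/c3ccccc3)N(Cc3ccncc3)C2=O)ccc1O` gives 28000 nM. The third value sits level with the first, at a 1.1-fold higher number from compound 1 to compound 3 (0.03 log units; within the scatter), and apart from the second, at a 2.3-fold higher number from compound 2 to compound 3 (0.35 log units; beyond the scatter). Compound 4 `COc1ccc(OC)c(/C=C2/S/C(=N/c3ccccc3)N(Cc3ccncc3)C2=O)c1` changes one place, on a double-bonded chain carbon bound to a double-bonded ring carbon, where 2,5-dimethoxyphenyl stands in place of 4-hydroxy-3-methoxyphenyl: 2,5-dimethoxyphenyl in place of 4-hydroxy-3-methoxyphenyl on a double-bonded chain carbon bound to a double-bonded ring carbon. Within the data shown here, no measured compound carries the entering group, so the evidence is indirect. Exchanging groups at this place has produced only small movements so far. The other step that passes the scatter is also modest, at a 2.1-fold lower number from compound 1 to compound 2 (0.33 log units; beyond the scatter), and the remaining one, given above, does not pass it. In this assay, the expected step is therefore none beyond the scatter, at a 1.1-fold lower number from compound 3 to compound 4 (0.03 log units; within the scatter). Compound 4 is estimated at 26000 nM, with an expected range of 12000 nM to 55000 nM.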

Compound 4, half-maximal inhibitory concentration: 37000 nM
The estimate for compound 4 lay 1.4-fold (0.15 log units) below the measured number, and the stated range covers the measured number.
By their numbers in this assay, from the lowest: compound 2; then compounds 1, 3 and 4 (each within the scatter of the next).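

In this assay, 2,5-dimethoxyphenyl in place of 4-hydroxy-3-methoxyphenyl, a change that leaves the entering group with no hydrogen-bond donor, gives no shift that can be told from the scatter, at a 1.3-fold higher number from compound 3 to compound 4 (0.12 log units; within the scatter), and the comparison with plain phenyl also stays within the scatter, at a 1.4-fold higher number from compound 1 to compound 4 (0.15 log units; within the scatter). Against 3,4-dihydroxyphenyl the step is larger but still modest, at a 3.0-fold higher number from compound 2 to compound 4 (0.47 log units; beyond the scatter), so compound 2 now stands apart from each of the other three compounds, while compounds 1, 3 and 4 form a single group. No measured evidence accounts for these differences.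

Going by these compounds, whether an amine or a carboxylic acid at this place would move the number further remains open. So does whether changes elsewhere on the shared core would produce larger steps than this place has given.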